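From butyl to trifluoromethyl on a shared core

The source may hold more compounds than are shown below. What is called first, only, known or untested is meant among the compounds shown, and "the series" means these compounds.

Compound 1 `N=c1sc2cc(OC(F)(F)F)ccc2n1CCCN1CCN(c2ccccc2)CC1` gives 10 mg/kg
Compound 2 `CCCCc1ccc2c(c1)sc(=N)n2CC[S+]([O-])CC` gives > 10 mg/kg (a limit, not a number)

The read-out here is a functional assay on the whole organism with Rattus norvegicus as the target; on this read-out lower numbers stand for an effect already at smaller amounts and higher numbers for an effect only at larger amounts of compound. In it, compound 1 gives a true number, 10 mg/kg. Compound 2 stands only at a limit of the assay, > 10 mg/kg, so its real dose is not known. The same limit is noted here as the limit of > 10 mg/kg in this assay, at which 1 of the 2 values shown sits.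

The next compound, compound 3 `CC[S+]([O-])CCn1c(=N)sc2cc(C(F)(F)F)ccc21`, has trifluoromethyl in place of butyl on an aromatic carbon, and the change counts as trifluoromethyl in place of butyl on an aromatic carbon. Within the data shown here, no measured pair of compounds shows what this swap does in this assay, so any expectation is loose. Among the measured compounds shown here, compound 1 also carries fluorine and gives 10 mg/kg, which is the only firm number to lean on. A modest move towards smaller doses therefore seems more likely than a large one. The estimated change is an at least 1.4-fold lower number from compound 2 to compound 3 (0.15 log units; that floor lies within the scatter). For compound 3 the expected value is 7 mg/kg, with an estimated range from 2 mg/kg to 20 mg/kg. The result could also turn out to be a limit again.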

Compound 3, dose for half-maximal effect: 1.7 mg/kg
Beside the measured number, compound 3's estimate is 4.1-fold (0.61 log units) above it; the whole stated range lies above it.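

This pair gives the first measured view of this position: on the aromatic carbon of the shared core, trifluoromethyl in place of butyl gives an at least 5.8-fold lower number from compound 2 to compound 3 (0.76 log units; beyond the scatter) in this assay. The two groups match in their counts under the computed comparison, with the same number of heavy atoms, no ring and no hydrogen-bond donors or acceptors, so those counts do not separate them, and what differs is the kind of atom, carbon against fluorine. Going by these compounds, the true size of the step remains unknown because compound 2 stands only at a limit of the assay, which makes the step a floor rather than a measured difference: the limit of > 10 mg/kg in this assay, at which 1 of the 3 values shown sits.

On these data alone, with only butyl and trifluoromethyl compared here, it remains open whether a chlorine atom, a methoxy group or a plain hydrogen at this position would give a number like that of compound 3 or stay at the limit like compound 2. Compound 1 differs from compound 3 in more than one place, so it cannot show how much of its effect belongs to the group on the aromatic carbon and how much to its longer side chain.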